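Hydroxy for amino on the cyclohexyl ring

The source may hold more compounds than are shown below. What is called first, only, known or untested is meant among the compounds shown, and "the series" means these compounds.

In a functional assay on HCT-116 cells (Homo sapiens) for inhibition, with a stated time of 72 h (on this read-out higher numbers stand for weaker inhibition and lower numbers for stronger inhibition), compound 1 (`NC1CCC(Nc2nc(NCc3ccc(-n4cccn4)cc3)c3ncn(C4CCCC4)c3n2)CC1`) gives 320 nM as its reading. Compound 2 (`NC1CCC(Nc2nc(NCc3ccc(-c4ccco4)nc3)c3ncn(C4CCCC4)c3n2)CC1`) gives 86 nM and compound 3 (`NC1CCC(Nc2nc(NCc3ccc(-c4cccs4)nc3)c3ncn(C4CCCC4)c3n2)CC1`) gives 97 nM in the same test. Compound 2 and compound 3 sit level, with a 1.1-fold higher number from compound 2 to compound 3 (0.05 log units; within the scatter) as the step between them. Compound 1 stands higher than both, and the steps down from it are a 3.7-fold lower number from compound 1 to compound 2 (0.57 log units; beyond the scatter) and a 3.3-fold lower number from compound 1 to compound 3 (0.52 log units; beyond the scatter) as measured.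

Compound 4 (`OC1CCC(Nc2nc(NCc3ccc(-c4ccco4)nc3)c3ncn(C4CCCC4)c3n2)CC1`) alters compound 2 in one place, with hydroxy in place of amino on a saturated ring carbon. This turns 4-aminocyclohexyl into 4-hydroxycyclohexyl. Going by the values given here, no measured step touches this place, since compound 1, compound 2 and compound 3 all carry the amino group. Their steps therefore give no direction and serve only as a yardstick for what one change can do in this assay here. The largest of them is a 3.7-fold lower number from compound 1 to compound 2 (0.57 log units; beyond the scatter) and sets a modest scale. A rise of about that size is expected, though this direction is a judgement that the data do not test. The expected step is a 3.5-fold higher number from compound 2 to compound 4 (0.54 log units; beyond the scatter) with wide uncertainty. For compound 4 the estimated value is 300 nM and the expected range runs from 100 nM to 900 nM in this estimate.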

Compound 4, half-maximal inhibitory concentration: 617 nM
The estimate for compound 4 lay 2.1-fold (0.31 log units) below the measured number, and the stated range covers the measured number.
By their numbers in this assay, from the lowest: compounds 2 and 3 (each within the scatter of the next); then compounds 1 and 4 (each within the scatter of the next).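

In this assay, going by these compounds alone, hydroxy in place of amino on this saturated ring carbon gives a 7.2-fold higher number from compound 2 to compound 4 (0.86 log units; beyond the scatter), which means weaker inhibition and is the first reading of any change at this position. The result shows that this end of the molecule matters for the cell read-out: 4-aminocyclohexyl and 4-hydroxycyclohexyl differ by a single heavy atom and match in hydrogen-bond donors, hydrogen-bond acceptors and net charge, so those counts alone do not predict the step. Nothing among the available data explains why swapping nitrogen for oxygen here weakens inhibition.

The swap is shown only with the furan-2-yl compound, so whether amino holds the same advantage with the thiophen-2-yl group of compound 3 or the 4-(1H-pyrazol-1-yl)phenyl group of compound 1 remains open. It is also unclear how much the position depends on this particular amino group, a question that a methylamino, dimethylamino, aminomethyl or methoxy group on the same ring carbon could help to answer.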